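Compound 4: adding an amino acid group to compound 3

A few compounds are considered here, and "the series" means these few. Any claim that something is new, unique, unknown or untested is made for them only; others in the source may bear on it.

Measured so far in an ADME assay on MRC5 cells (Homo sapiens) for cytotoxicity, read by MTT assay, with a stated time of 72 h; on this read-out lower numbers stand for stronger inhibition and higher numbers for weaker inhibition:
compound 1 `CC(C)(C)C1=CC(=O)C=C(NCCC(=O)O)C1=O` gives > 200000 nM as a limit
compound 2 `CC1=CCC[C@H]2[C@](C)(CC3=CC(=O)C(N4CCC[C@H]4C(=O)O)=CC3=O)[C@@H](C)CC[C@]12C` gives 96000 nM as a number
compound 3 `CC1=CCC[C@H]2[C@](C)(CC3=CC(=O)C=CC3=O)[C@@H](C)CC[C@]12C` gives > 200000 nM as a limit

Within the data shown here, compound 3 stands only at a limit (> 200000 nM) and offers no exact number to step from. The change to compound 4 `CC1=CCC[C@H]2[C@](C)(CC3=CC(=O)C=C(N[C@@H](CC(C)C)C(=O)O)C3=O)[C@@H](C)CC[C@]12C` is (1-carboxy-3-methylbutyl)amino in place of hydrogen on a double-bonded ring carbon and amounts to (1-carboxy-3-methylbutyl)amino in place of hydrogen on a double-bonded ring carbon.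

Among the measured compounds shown here, one measured step bears on this change. Hydrogen in place of 2-carboxypyrrolidin-1-yl on a double-bonded ring carbon gave an at least 2.0-fold higher number from compound 2 to compound 3 (0.31 log units; beyond the scatter) and so lies beyond the scatter. Compound 2 keeps a number (96000 nM) with its group in place, so a modest step toward a lower number is expected in this assay for the reverse kind of change.

Compound 1 goes against any wider rule: it also carries an amino chain ending in a carboxylic acid, on a different core, and gives only a limit. Further caution comes from the limit of > 200000 nM in this assay, at which 2 of the 3 values shown sit, and compound 4 may likewise return only a limit.

The expected shift is an at least 2.2-fold lower number from compound 3 to compound 4 (0.34 log units; beyond the scatter) as a rough estimate. For compound 4 the estimated value is 90000 nM with an expected range from 35000 nM to 200000 nM on present evidence.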

Compound 4, half-maximal inhibitory concentration: 73400 nM
For compound 4 the middle estimate is 1.2-fold (0.09 log units) above the measured one; the measured number falls inside the stated range.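

In this assay, the (1-carboxy-3-methylbutyl)amino group on a double-bonded ring carbon, two ring bonds from the ring atom that bears a large group, gives an at least 2.7-fold lower number from compound 3 to compound 4 (0.43 log units; beyond the scatter). Among these compounds, until now the only step on the shared core rested on 2-carboxypyrrolidin-1-yl, so a group with its nitrogen outside any ring now also moves the read-out beyond the scatter. Compound 1, on a different core, goes against any wider rule: it also carries an amino chain ending in a carboxylic acid, and it gives > 200000 nM, which is a limit.

The full size of the step stays open because compound 3 offers only a limit and no exact number: the limit of > 200000 nM in this assay, at which 2 of the 4 values shown sit.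

Also open, as far as these compounds go, is how much of the step belongs to the carboxylic acid and how much to the amino chain, since a plain 3-methylbutylamino group or a methyl ester of the acid on the same ring carbon would separate the two.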